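An Amide Gives Way to a 1,2-Oxazole

The compounds below may be only part of what the source reports. "The series", "measured", "known", "first", "only" and "open" are said of these compounds alone.

In a functional assay on MIA PaCa-2 cells (Homo sapiens) for inhibition, read by MTT assay, with a stated time of 7 days (a higher number here means a weaker inhibitor, a lower number a stronger inhibitor), compound 2 `CCN(CC)C(=O)[C@@H]1CCCN(S(=O)(=O)c2ccc(S(=O)(=O)N(CC)CC)cc2)C1` gives 6400 nM, the highest of the three numbers recorded. Compound 1 `CCN(CC)S(=O)(=O)c1ccc(S(=O)(=O)N2CCC[C@@H](C(=O)NC3CN(C(=O)C4CC4)C3)C2)cc1` gives 2800 nM in this assay, and compound 3 `CCN(CC)S(=O)(=O)c1ccc(S(=O)(=O)N2CCC[C@@H](C(=O)NC3CN(C(=O)OC(C)(C)C)C3)C2)cc1` gives 200 nM. Compound 4 `CCN(CC)S(=O)(=O)c1ccc(S(=O)(=O)N2CCC[C@@H](c3cc(C)no3)C2)cc1` differs from compound 2 by 3-methyl-1,2-oxazol-5-yl in place of diethylcarbamoyl on a saturated ring carbon. The three measured steps all vary the group on the carbonyl carbon: a 2.3-fold higher number from compound 1 to compound 2 (0.36 log units; beyond the scatter), a 14-fold lower number from compound 1 to compound 3 (1.15 log units; beyond the scatter) and a 32-fold lower number from compound 2 to compound 3 (1.51 log units; beyond the scatter). None of them removes the carbonyl itself, so they bear on the new step only loosely; they show that compound 2 is the weakest point of this small set, leaving room in either direction. A step of a 1.6-fold lower number from compound 2 to compound 4 (0.20 log units; within the scatter) is expected, and compound 4 is estimated at 4000 nM, within a range of 800 nM to 20000 nM.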

Compound 4, half-maximal inhibitory concentration: 4900 nM
For compound 4 the middle estimate is 1.2-fold (0.09 log units) below the measured one; the measured number falls inside the stated range.
By their numbers in this assay, from the lowest: compound 3; then compounds 1, 4 and 2 (each within the scatter of the next, the first and the last beyond it).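

Among the compounds shown here, all the earlier steps kept the carbonyl on this saturated ring carbon, whereas here the whole diethylcarbamoyl group gives way to 3-methyl-1,2-oxazol-5-yl, and this assay shows a 1.3-fold lower number from compound 2 to compound 4 (0.12 log units; within the scatter) for the exchange. In this one pair, then, a five-membered aromatic ring can stand in place of the amide without a reading beyond the scatter. No measurement shown accounts for this result. As far as these compounds go, it remains open whether the methyl on the new ring matters, and whether a carboxylic acid or a primary amine on this ring carbon would read differently.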